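A few compounds are considered here, and "the series" means these few. Any claim that something is new, unique, unknown or untested is made for them only; others in the source may bear on it.

Three compounds share one core, differing only in the aryl group on an amide-type nitrogen in a ring. Compound 1 `COc1ncc(-c2ccc3c(c2)N(c2ccc(F)cc2)C(=O)CO3)cc1NS(=O)(=O)c1ccc(F)cc1` carries a 4-fluorophenyl there, compound 2 `COc1ncc(-c2ccc3c(c2)N(c2ccc(Cl)cc2)C(=O)CO3)cc1NS(=O)(=O)c1ccc(F)cc1` a 4-chlorophenyl, and compound 3 `COc1cccc(N2C(=O)COc3ccc(-c4cnc(OC)c(NS(=O)(=O)c5ccc(F)cc5)c4)cc32)c1` a 3-methoxyphenyl. In a functional assay on A549 cells (Homo sapiens) for antiproliferative activity, read by MTT assay, with a stated time of 72 h (a higher number here means a weaker inhibitor, a lower number a stronger inhibitor), compound 1 gives 6500 nM, compound 2 gives 8350 nM and compound 3 gives 11200 nM. Compound 3 shows the highest of the three numbers, yet its steps to the others stay within the scatter: a 1.3-fold higher number from compound 2 to compound 3 (0.13 log units; within the scatter) and a 1.7-fold higher number from compound 1 to compound 3 (0.24 log units; within the scatter). The three cannot be ranked on these data.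

Compound 4 `COc1ncc(-c2ccc3c(c2)N(c2ccccc2)C(=O)CO3)cc1NS(=O)(=O)c1ccc(F)cc1` arises from compound 3 by hydrogen in place of methoxy on an aromatic carbon. Among the measured compounds shown here, the steps that bear on this are those already seen on the same aryl group, a 1.7-fold higher number from compound 1 to compound 3 (0.24 log units; within the scatter) and a 1.3-fold higher number from compound 2 to compound 3 (0.13 log units; within the scatter), and neither left the scatter. Exchanging one small substituent on this ring has so far not moved the number beyond the usual variation, so no step beyond the scatter is expected here either. Both recorded steps run in the same direction, which gives a faint lean toward a lower number. For compound 4 the expected step is a 1.3-fold lower number from compound 3 to compound 4 (0.12 log units; within the scatter). Compound 4 is therefore estimated at 8500 nM, with a range from 4000 nM to 18000 nM.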

Compound 4, half-maximal inhibitory concentration: 3490 nM
Compound 4: middle estimate off by 2.4-fold (0.39 log units), on the high side, and the stated range ends above it.
By their numbers in this assay, from the lowest: compounds 4, 1, 2 and 3 (each within the scatter of the next, the first and the last beyond it).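

In this assay, among the compounds shown here, the plain phenyl ring gives the first steps that leave the scatter: hydrogen in place of methoxy gives a 3.2-fold lower number from compound 3 to compound 4 (0.51 log units; beyond the scatter), and hydrogen in place of chloro gives a 2.4-fold lower number from compound 2 to compound 4 (0.38 log units; beyond the scatter), both modest. Hydrogen in place of fluoro, with a 1.9-fold lower number from compound 1 to compound 4 (0.27 log units; within the scatter), stays within the scatter, so compound 1 cannot be told apart from compound 4, and it stands against any rule that every substituent on this ring raises the number. The swaps among substituents showed no clear effect, but the comparison with hydrogen shows that this aryl group on the amide-type nitrogen is not indifferent to change, although no measurement shown here explains the difference.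

The compounds shown leave open how this ring would respond to other groups, such as an amine, a carboxylic acid or a longer chain like ethoxy. For the compounds shown here, they also leave open whether a methoxy placed elsewhere on this ring would give the same result as the one in compound 3.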